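Amino in place of hydrogen on compound 1

The compounds below may be only part of what the source reports. "The series", "measured", "known", "first", "only" and "open" are said of these compounds alone.

Measured in a physicochemical assay for lipophilicity, at pH 7.4; a lower number here means a more polar compound, a higher number a more lipophilic compound:
Compound 1 `CCc1ccc(N(CC(C)C)S(=O)(=O)c2ccc3c(c2)CCC(C2CCOCC2)O3)cc1` gives 5.38
Compound 2 `CCc1ccc(N(CC(C)C)S(=O)(=O)c2ccc3c(c2)C(O)CC(C2CCNCC2)O3)cc1` gives 1.04
Compound 3 `Cc1cc(C(O)(C(F)(F)F)C(F)(F)F)ccc1N(CC(C)C)S(=O)(=O)c1ccc2c(c1)C(O)CC(C1CCOCC1)O2` gives 4.37

Compound 1 stands highest of the three. Its gaps to compound 3 and to compound 2, the furthest of the set, both lie beyond the usual scatter. Compound 4 `CCc1ccc(N(CC(C)C)S(=O)(=O)c2ccc3c(c2)C(N)CC(C2CCOCC2)O3)cc1` has not yet been measured. It departs from compound 1 in one place: amino in place of hydrogen on a saturated ring carbon. This is amino in place of hydrogen on a saturated ring carbon, two ring bonds from the ring atom that bears the oxan-4-yl group.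

Within the data shown here, no two measured compounds differ in one place only, so no measured step speaks directly to this change. Among the measured compounds shown here, the only indirect guide is compound 2, the one measured compound with a nitrogen carrying hydrogen, which reads 1.04. For the measured compounds named here, it differs from compound 1 in more than one place, so it sets no size for the step. A fall in this assay beyond the scatter is expected, smaller than the gap between the values of compound 1 and compound 2. The estimated step is a number 2.18 log units lower from compound 1 to compound 4 (beyond the scatter). For compound 4 the expected value is 3.2, with an estimated range from 2.3 to 4.1.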

Compound 4, distribution coefficient: 3.08
Compound 4: middle estimate off by 0.12 log units, on the high side; the measured number falls inside the stated range.
By their numbers in this assay, from the lowest: compound 2; then compound 4; then compound 3; then compound 1.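

In this assay, among these compounds, amino in place of hydrogen on a saturated ring carbon, two ring bonds from the ring atom that bears the oxan-4-yl group, gives the first step that can be read at a single place: a number 2.30 log units lower from compound 1 to compound 4 (beyond the scatter). The earlier compounds shown here all differed from each other in more than one place, so they set no size for any single change, whereas this result shows that this one substitution on the core of compound 1 is enough on its own to produce a large fall. Nothing measured here accounts for the size of this fall.

Still open, on these data alone, is whether a dimethylamino group or a carboxylic acid on the same saturated ring carbon would give a step of similar size or a different one. Also open, as far as these compounds go, is whether amino in place of hydrogen would give a comparable step elsewhere on the shared core, since this single pair speaks for this one position and this one group only.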